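Diphenylsulfanyl Quinolinedione: An Expectation From Sparse Data

This account rests on a few compounds, and the source may have more. Where it says the series, first, only, none or still open, it means among the compounds named here.

Compound 1, `CNC1=C(Cl)C(=O)c2ncccc2C1=O`, in a functional assay on cells (Neutrophil, Homo sapiens) for inhibition, read by WST assay, with a stated time of 20 min (a higher number here means a weaker inhibitor, a lower number a stronger inhibitor), gives 78900 nM.
Compound 2, `CNC1=C(Sc2ccccc2)C(=O)c2ncccc2C1=O`, in this assay gives only a limit, > 150000 nM.
Compound 3, `CNC1=C([S+](C)[O-])C(=O)c2ncccc2C1=O`, in this assay gives only a limit, > 200000 nM.

Compound 2 thus stands at a limit of this assay rather than at a number, as recorded in the limit of > 150000 nM in this assay, at which 1 of the 3 values shown sits. For the measured compounds named here, compound 1 is the only member of this set with a measured number. The step from compound 1 to compound 2, which exchanged chloro for phenylsulfanyl, was an at least 1.9-fold higher number from compound 1 to compound 2 (0.27 log units; that floor lies within the scatter). The step to compound 3 was an at least 2.5-fold higher number from compound 1 to compound 3 (0.40 log units; beyond the scatter). Between compound 2 and compound 3 the step is a step that the two limits leave unreadable from compound 2 to compound 3.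

Compound 4, `O=C1C(Sc2ccccc2)=C(Sc2ccccc2)C(=O)c2ncccc21`, differs from compound 2 by phenylsulfanyl in place of methylamino on a double-bonded ring carbon. Going by the values given here, no measured step in this set exchanges methylamino for anything, so the measured steps give no direct guide to this change. Among the compounds with values here, they show only that the shared core, once chloro is replaced, sits at the limit of this assay. Compound 4 is therefore expected to remain at or beyond that limit, with a step that the limit leaves unreadable from compound 2 to compound 4 being the estimate. The estimated value for compound 4 is 200000 nM, within a range from 70000 nM to 600000 nM.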

Compound 4, half-maximal inhibitory concentration: 24800 nM
Estimate against measurement, compound 4: 8.1-fold (0.91 log units) above; measured number below the stated range.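

The earlier compounds shown here varied only the group that chloro occupies in compound 1, and every such change ended at a limit. Compound 4 shows that the other double-bonded ring carbon also matters: with phenylsulfanyl in place of methylamino, next to the ring atom that bears a phenylsulfanyl group, this assay records an at least 6.0-fold lower number from compound 2 to compound 4 (0.78 log units; beyond the scatter). The exchange also removes the hydrogen-bond donor of methylamino, and the size of the step is known only as a floor because compound 2 stands at a limit: the limit of > 150000 nM in this assay, at which 1 of the 4 values shown sits.

The compounds shown cannot separate the entry of phenylsulfanyl from the departure of methylamino. A dimethylamino or methylsulfanyl group at this position, or chloro kept on the neighbouring ring carbon, would bear on that question.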